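Replacing the aromatic ring on the ether oxygen

The source may report more compounds than this note shows. Statements on the series, on what has been measured and on what is new or still open speak of the compounds shown alone.

Measured so far in an ADME assay on a cell-free system (plasma, Rattus norvegicus, strain Sprague-Dawley) for protein binding:
compound 1 `COc1ccc(NC(=O)Nc2cc(F)cc(Oc3cccnc3)c2)cc1` gives 95.1%
compound 2 `COc1ccc(NC(=O)Nc2cc(F)cc(Oc3cccnc3)c2)cn1` gives 92.5%
compound 3 `O=C(Nc1cccnc1)Nc1cc(F)cc(Oc2cccnc2)c1` gives 92.9%

Compound 3 stands level with the other two, and the steps show this: a 1.4-fold higher unbound fraction from compound 1 to compound 3 (0.16 log units; within the scatter), a 1.1-fold lower unbound fraction from compound 2 to compound 3 (0.02 log units; within the scatter) and a 1.5-fold higher unbound fraction from compound 1 to compound 2 (0.18 log units; within the scatter).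

Compound 4 `CC(=O)N1CCC[C@@H](Oc2cc(F)cc(NC(=O)Nc3cccnc3)c2)C1` differs from compound 3 in one place: 1-acetylpiperidin-3-yl in place of pyridin-3-yl on an oxygen on an aromatic ring. For the measured compounds named here, none of the measured steps touches that oxygen, so their small size is only weak guidance. A modest move towards more free compound is expected, possibly just beyond the scatter. The estimated step is a 2.1-fold higher unbound fraction from compound 3 to compound 4 (0.32 log units; beyond the scatter) in this assay. Compound 4 is expected at 85%, with an estimated range of 70% to 93%.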

Compound 4, plasma protein binding: 82.5%
For compound 4 the middle estimate is 1.2-fold (0.07 log units) (unbound fraction) below the measured one; the range from low to high includes it.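

In this assay, the oxygen on the aromatic ring proves to be a place where the substituent matters: moving from pyridin-3-yl to 1-acetylpiperidin-3-yl leaves more compound free (a 2.5-fold higher unbound fraction from compound 3 to compound 4 (0.39 log units; beyond the scatter)). The earlier steps shown here, all made elsewhere on the molecule, stayed within the scatter. No measurement available here explains this rise.

This single swap replaces an aromatic ring with a non-aromatic one and also brings in the acetyl group, and the compounds shown do not separate these two changes. From the compounds shown here alone, how a piperidine with a free amine or a simple methyl group on the oxygen would behave remains open.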